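The source may hold more compounds than are shown below. What is called first, only, known or untested is meant among the compounds shown, and "the series" means these compounds.

Working notes on the series in a functional assay on the whole organism (Abdomen, strain Swiss albino) for inhibition, with Mus musculus as the target, in the writhing test, with a stated time of 30 min, at a dose of 30 mg/kg by the oral route; a higher number here means more inhibition at the dose given (going by the name of the read-out), a lower number less inhibition. Of the compounds shown here, three of a shared core have numbers so far. Compound 1 `O=C(O)[C@H]1CCC[C@@H](c2ccc3ccccc3c2)O1` gives 43.1% in this assay. Compound 2 `O=C(O)[C@H]1CCC[C@@H](c2cccc3ccccc23)O1` gives 49% in this assay. Compound 3 `OC[C@H]1CCC[C@@H](c2cccc3ccccc23)O1` gives 39.2% in this assay. Compound 2 carries the highest of the three numbers, but its gap to compound 1 and its gap to compound 3 both lie within the scatter, so the three numbers cannot be ordered with confidence.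

Among the measured compounds shown here, only one step between compounds that differ in one place has been measured: a number 9.8 percentage points lower from compound 2 to compound 3 (within the scatter). That step concerns the group on the saturated ring carbon next to the ring oxygen that carries the carboxy group, and it stays within the scatter.

Compound 4 `O=C(O)[C@H]1C[C@@H](Cl)C[C@@H](c2cccc3ccccc23)O1` is not yet measured. It differs from compound 2 by chloro in place of hydrogen on a saturated ring carbon. For the measured compounds named here, no measured step touches a halogen on the saturated ring, so nothing measured bears directly on this change; the one step available, from carboxy to hydroxymethyl, gives no guidance on it. Going by the values given here, with no step beyond the scatter, a step within the scatter is expected, a number 2 percentage points lower from compound 2 to compound 4 (within the scatter). For compound 4 the expected value in this assay is 47%, estimated to lie between 30% and 64%.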

Compound 4, a percentage reported as inhibition, in the whole organism at one dose (the size of the read-out at that dose, not a potency): 54.4%
Estimate against measurement, compound 4: 7.4 percentage points below, within the range that was stated.
By their numbers in this assay, from the lowest: compounds 3, 1, 2 and 4 (each within the scatter of the next, the first and the last beyond it).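

In this assay, chloro in place of hydrogen on a saturated ring carbon, two ring bonds from the ring atom that bears a carboxy group and two ring bonds from the ring atom that bears a large group, gives a number 5.4 percentage points higher from compound 2 to compound 4 (within the scatter), so compound 2 and compound 4 cannot be ordered. The earlier step concerned only the carboxy group, whereas this one shows that a chloro group can stand at this second place on the saturated ring with a number that cannot be told apart from that of the parent compound. Nothing on hand explains this result or ties it to any property of the chloro group.

Open questions are whether fluoro, bromo, hydroxy, methyl or an amine at this same ring carbon would give a step beyond the scatter, or would also stay within it. Going by these compounds, it is also open whether chloro at this place would give a similar step on the core of compound 1 or alongside the hydroxymethyl group of compound 3.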